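An acylated ring nitrogen on compound 1

The source may hold more compounds than are shown below. What is called first, only, known or untested is meant among the compounds shown, and "the series" means these compounds.

In a functional assay on U-87MG ATCC cells (Homo sapiens) for antiproliferative activity (on this read-out higher numbers stand for weaker inhibition and lower numbers for stronger inhibition), compound 1 `Cc1c2c(n3c1CCCN(C)[C@@H](C)[C@H](C)Nc1cc-3ccc1C(N)=O)CC(C)(C)CC2=O` reads 133 nM and stands highest of the three measured compounds, which makes it the weakest inhibitor among them. Compound 2 `Cc1c2c(n3c1CCN(C)C[C@@H](C)[C@H](C)Nc1cc-3ccc1C(N)=O)CC(C)(C)CC2=O` comes in at 49 nM on the same read-out, and compound 3 `CC(=O)N1CCc2c(C)c3c(n2-c2ccc(C(N)=O)c(c2)N[C@@H](C)[C@H](C)C1)CC(C)(C)CC3=O` comes in at 24 nM there. Compound 4 `Cc1c2c(n3c1CCCN(C(=O)CO)[C@@H](C)[C@H](C)Nc1cc-3ccc1C(N)=O)CC(C)(C)CC2=O` has not yet been measured. It keeps the core of compound 1 but carries (hydroxymethyl)carbonyl in place of methyl on an amine nitrogen in a ring, a change counted as (hydroxymethyl)carbonyl in place of methyl on an amine nitrogen in a ring in full. Among the measured compounds shown here, one measured step bears on this: acetyl in place of methyl on an amine nitrogen in a ring gave a 2.0-fold lower number from compound 2 to compound 3 (0.31 log units; beyond the scatter) on this read-out, a modest change. The guide is imperfect. Compound 2 and compound 3 do not share the core of compound 1, and acetyl is not the entering group, so nothing measured shows what the extra hydroxymethyl part does. For the measured compounds named here, a modest fall in the number is therefore expected, in line with a 2.0-fold lower number from compound 2 to compound 3 (0.31 log units; beyond the scatter) as the only precedent. The expected change is a 2.2-fold lower number from compound 1 to compound 4 (0.35 log units; beyond the scatter) in size and direction. The estimate for compound 4 is 60 nM (expected range 20 nM to 170 nM).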

Compound 4, half-maximal inhibitory concentration: 111 nM
Compound 4: the middle estimate sits 1.9-fold (0.27 log units) below what was measured, and the stated range covers the measured number.
By their numbers in this assay, from the lowest: compound 3; then compound 2; then compounds 4 and 1 (each within the scatter of the next).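

In this assay, placing (hydroxymethyl)carbonyl on the amine nitrogen in the ring of compound 1 gave a 1.2-fold lower number from compound 1 to compound 4 (0.08 log units; within the scatter), so exchanging the methyl for this larger group, with its hydrogen-bond donor and acceptors, left the number within the scatter. The earlier acyl step, a 2.0-fold lower number from compound 2 to compound 3 (0.31 log units; beyond the scatter), lay beyond the scatter, and the present result shows that such a fall does not appear for every acyl group on every core of this set. Nothing measured here accounts for the difference between the two steps.

The compounds shown leave open whether the core or the hydroxymethyl part of the entering group sets the two steps apart, as acetyl appears only on the core shared by compound 2 and compound 3 and (hydroxymethyl)carbonyl only on the core of compound 1. On these data alone, how this nitrogen would respond to methoxyacetyl, to aminoacetyl, to a longer acyl chain or to a group ending in a carboxylic acid also remains open.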